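From isopropyl to ethyl on the shared core

The source may report more compounds than this note shows. Statements on the series, on what has been measured and on what is new or still open speak of the compounds shown alone.

Measured so far in a physicochemical assay for lipophilicity, measured as octanol-water partition; a lower number here means a more polar compound, a higher number a more lipophilic compound
compound 1 `CC(C)(C)c1ccc(/C=C/C(=O)N[C@@H]2O[C@H](CO)[C@@H](O)[C@H](O)[C@H]2O)cc1` gives 0.496
compound 2 `CC(C)c1ccc(/C=C/C(=O)N[C@@H]2O[C@H](CO)[C@@H](O)[C@H](O)[C@H]2O)cc1` gives 0.296
compound 3 `Cc1ccc2c(c1)C=C(C(=O)N[C@@H]1O[C@H](CO)[C@@H](O)[C@H](O)[C@H]1O)C(=O)C2` gives -0.451

Compound 2 (at 0.296) cannot be told apart from compound 1 (at 0.496), while compound 3 (at -0.451) stands lower, beyond the scatter.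

The next compound is compound 4 `CCc1ccc(/C=C/C(=O)N[C@@H]2O[C@H](CO)[C@@H](O)[C@H](O)[C@H]2O)cc1` and the change from compound 2 is isopropyl to ethyl (hydrogen in place of methyl on a saturated chain carbon bound to an aromatic carbon and a saturated chain carbon). This puts hydrogen in place of methyl on a saturated chain carbon bound to an aromatic carbon and a saturated chain carbon.

Going by the values given here, one measured step bears on this (a number 0.20 log units lower from compound 1 to compound 2 (within the scatter)). It also puts hydrogen in place of methyl, on a saturated chain carbon bound to an aromatic carbon and two saturated chain carbons. It is a single precedent, and it stays within the scatter. Among the compounds with values here, no measured step links compound 3 to the other compounds, so it offers no guide here.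

A small fall of similar size is therefore expected in this assay, with no firm expectation of a change beyond the scatter. The expected change is small (a number 0.20 log units lower from compound 2 to compound 4 (within the scatter)). For compound 4 the estimated value is 0.1 (expected range -0.2 to 0.4).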

Compound 4, partition coefficient: 0.04
For compound 4 the middle estimate is 0.06 log units above the measured one; the measured number falls inside the stated range.
By their numbers in this assay, from the lowest: compound 3; then compounds 4, 2 and 1 (each within the scatter of the next, the first and the last beyond it).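

In this assay, the second removal of a methyl from the carbon bound to the aromatic ring is again a step that stays within the scatter (a number 0.26 log units lower from compound 2 to compound 4 (within the scatter)), as the first one did (a number 0.20 log units lower from compound 1 to compound 2 (within the scatter)). Taken together, the two steps give the first difference on this aromatic carbon that can be told apart, ethyl in place of tert-butyl (a number 0.46 log units lower from compound 1 to compound 4 (beyond the scatter)), which lies beyond the scatter, so the three compounds with these groups can be separated only at their two ends. No measurement at hand accounts for the size of these steps.

Among the shown compounds, this reading rests on three groups on the shared core, with one step for each pair, and it does not tell whether the numbers would keep the same direction with methyl or a lone hydrogen on that aromatic carbon, or how a longer chain such as n-butyl would compare. As far as these compounds go, an amine or a carboxylic acid at the same place also stays open, as does any link between compound 3 and the other compounds.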